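Notes on a 2,4-dichlorophenyl for 4-bromophenyl swap

This account rests on a few compounds, and the source may have more. Where it says the series, first, only, none or still open, it means among the compounds named here.

Measured so far in a functional assay on K562 cells (Homo sapiens) for cytotoxicity, read by MTT assay, with a stated time of 24 h; a lower number here means a stronger inhibitor, a higher number a weaker inhibitor:
compound 1 `COc1cc(/C=C2\CN(C)C/C(=C\c3ccc(Br)cc3)C2=O)cc(OC)c1OC` gives 12400 nM.
compound 2 `COc1cc(/C=C2\CN(C)C/C(=C\c3ccc(Cl)cc3Cl)C2=O)cc(OC)c1OC` gives > 20000 nM, which is a limit of the assay and not a number.
compound 3 `CN1C/C(=C\c2ccc(Br)cc2)C(=O)/C(=C/c2ccc(C#N)cc2)C1` gives 7420 nM.

Compound 1 and compound 3 differ in more than one place; the difference between the two cores is not broken down here. In this assay compound 3 and compound 1 read within the usual scatter of each other, so no order between them is claimed. From compound 1 to compound 2 the change is 2,4-dichlorophenyl in place of 4-bromophenyl on a double-bonded chain carbon bound to a double-bonded ring carbon. It made an at least 1.6-fold higher number from compound 1 to compound 2 (0.20 log units; that floor lies within the scatter), a step whose floor sits within the scatter and which ends at the limit of > 20000 nM in this assay, at which 1 of the 3 values shown sits.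

Compound 4 `CN1C/C(=C\c2ccc(C#N)cc2)C(=O)/C(=C/c2ccc(Cl)cc2Cl)C1` is not yet measured in this assay. It carries the same kind of change on the core of compound 3: 2,4-dichlorophenyl in place of 4-bromophenyl on a double-bonded chain carbon bound to a double-bonded ring carbon. Compound 4 is expected to show a 2.0-fold higher number from compound 3 to compound 4 (0.31 log units; beyond the scatter) because after the same change compound 2 reached (the limit of > 20000 nM in this assay, at which 1 of the 3 values shown sits). Compound 4 is estimated at 15000 nM, within 7000 nM to 30000 nM, with a real chance that only a limit is reported.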

Compound 4, half-maximal inhibitory concentration: 11900 nM
For compound 4 the middle estimate is 1.3-fold (0.10 log units) above the measured one; measured number inside the range.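

In this assay, 2,4-dichlorophenyl in place of 4-bromophenyl on the core of compound 3 gives a 1.6-fold higher number from compound 3 to compound 4 (0.21 log units; within the scatter), so on this core the swap has no effect that can be told from the scatter. Set beside the same change on the core of compound 1, the result does not separate the two cores: the same change on two cores in this assay, an at least 1.6-fold higher number (0.20 log units; that floor lies within the scatter) from compound 1 to compound 2 and a 1.6-fold higher number (0.21 log units; within the scatter) from compound 3 to compound 4; the limit leaves it open whether they differ. Compound 2 gives > 20000 nM, which is a limit of the assay and not a number, so these data neither show that the change carries over between the cores with the same size nor show that its size depends on the core.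

The compounds shown leave open whether a phenyl ring bearing an amine or a carboxylic acid, placed on the same double-bonded chain carbon, would give a step beyond the scatter on either core. They also leave open whether the swap would read the same way outside this assay.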